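Hydroxymethyl in place of sec-butyl: an expected small step

The source may hold more compounds than are shown below. What is called first, only, known or untested is meant among the compounds shown, and "the series" means these compounds.

Compound 1 `O=C(O)[C@@H]1CCCN1C(=O)CN(c1nc(Cl)nc2[nH]cnc12)C1CC1` and compound 2 `CC[C@H](C)[C@H](NC(=O)CN(c1nc(Cl)nc2[nH]cnc12)C1CC1)C(=O)O` share one core and differ only in the acid-bearing part. In a functional assay on the whole organism (Tail, strain ICR) with Mus musculus as the target, in the tail flick test, with a stated time of 30 min, at a dose of 25 umol/kg by the oral route (on this read-out higher numbers stand for a stronger effect at the one dose given and lower numbers for a weaker effect), compound 1 gives 31.5%, and compound 2 gives 30.3%; these two numbers lie within the scatter of each other, so neither stands apart. Compound 3 `O=C(CN(c1nc(Cl)nc2[nH]cnc12)C1CC1)N[C@@H](CO)C(=O)O` has not yet been measured. It differs from compound 2 by hydroxymethyl in place of sec-butyl on a saturated chain carbon bound to an amide-type nitrogen and a carbonyl carbon. Among the measured compounds shown here, no measured pair shows what this change does, so only a step of about the scatter, perhaps slightly downward, is expected in this assay: a number 3.3 percentage points lower from compound 2 to compound 3 (within the scatter). Compound 3 is therefore expected to give 27%, between 10% and 45%.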

Compound 3, a percentage reported as activity, at one dose (the size of the read-out at that dose, not a potency): 38.7%
Estimate against measurement, compound 3: 11.7 percentage points below, within the range that was stated.
By their numbers in this assay, from the lowest: compounds 2, 1 and 3 (each within the scatter of the next).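

In this assay, among the compounds shown here, the first measured pair for this change, hydroxymethyl in place of sec-butyl, gives a number 8.4 percentage points higher from compound 2 to compound 3 (within the scatter) and so shows no effect that can be told from noise at this position. Replacing 2-carboxypyrrolidin-1-yl with (1-carboxy-2-hydroxyethyl)amino on a carbonyl carbon likewise gives a number 7.2 percentage points higher from compound 1 to compound 3 (within the scatter) and separates nothing. Nothing measured here offers an explanation for these numbers. Open, going by these compounds, is whether an amine, a phenyl ring or a longer chain on this saturated chain carbon would give a step beyond the scatter.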